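Cytotoxicity limits across three analogues of one amide series

The source may hold more compounds than are shown below. What is called first, only, known or untested is meant among the compounds shown, and "the series" means these compounds.

Measured so far in an ADME assay on CCRF-CEM cells (Homo sapiens) for cytotoxicity; a lower number here means that less compound is tolerated, a higher number that more compound is tolerated:
compound 1 `COC(=O)[C@H](CO)NC(=O)c1cnc2c(C)cccc2c1Cl`: > 100 uM
compound 2 `COC(=O)[C@H](CO)NC(=O)c1cnc2ccc(C)cc2c1Cl`: > 100 uM
compound 3 `COC(=O)[C@H](CO)NC(=O)c1cnc2c(Cl)cccc2c1Cl`: > 100 uM

Compound 2 stands at the limit of this assay, so no number is read for it. Compound 1 and compound 3 also stand at the limit, and the step that the two limits leave unreadable from compound 1 to compound 3 is therefore unreadable; the limit of > 100 uM in this assay, at which 3 of the 3 values shown sit, records where all three values sit. Compound 4 `COC(=O)[C@H](CO)NC(=O)c1cnc2ccc(F)cc2c1Cl` is not yet measured. Its change from compound 2 is fluoro in place of methyl on an aromatic carbon. Among the measured compounds shown here, no measured step bears on this change with a readable size, so no direction can be drawn from them, and the expectation for compound 4 is a step that the limit leaves unreadable from compound 2 to compound 4 that does not leave the limit. Compound 4 is estimated at 150 uM in this assay, within 50 uM to 400 uM.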

Compound 4, half-maximal toxic concentration: > 100 uM
Compound 4: no number, only a limit; the forecaster's own chance of this, stated with the estimate: 85%; the middle value lies beyond the limit too.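

No new step can be read between compound 2 and compound 4 in this assay, because both values are limits: the limit of > 100 uM in this assay, at which 4 of the 4 values shown sit.

The compounds shown leave open at what concentration any of them becomes toxic, and whether fluoro in place of methyl changes that concentration.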